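This account rests on a few compounds, and the source may have more. Where it says the series, first, only, none or still open, it means among the compounds named here.

In a functional assay on K562 cells (Homo sapiens) for inhibition, read by trypan blue exclusion, with a stated time of 72 h (on this read-out lower numbers stand for stronger inhibition and higher numbers for weaker inhibition), compound 1 `O=c1c(S(=O)(=O)c2ccc(F)cc2F)cc2cnc(Nc3ccc4[nH]ccc4c3)nc2n1C1CC1` gives 500 nM.
In this assay compound 2 `CN1CCN(c2ccc(Nc3ncc4cc(S(=O)(=O)c5ccc(F)cc5F)c(=O)n(C)c4n3)cc2)CC1` gives 5000 nM.
In this assay compound 3 `O=c1c(S(=O)(=O)c2ccc(F)cc2F)cc2cnc(Nc3ccc4[nH]ccc4c3)nc2n1CC1CCCC1` gives 7000 nM.

Compound 3 stands apart from compound 1 by a gap beyond the scatter, while its gap to compound 2 lies within the scatter. Compound 4 `COC(=O)Cn1c(=O)c(S(=O)(=O)c2ccc(F)cc2F)cc2cnc(Nc3ccc4[nH]ccc4c3)nc21` differs from compound 3 by methoxycarbonyl in place of cyclopentyl on a saturated chain carbon bound to an aromatic nitrogen. For the measured compounds named here, the only measured step at this place, a 14-fold higher number from compound 1 to compound 3 (1.15 log units; beyond the scatter), shows that the group on the aromatic nitrogen can move the number a great deal. Going by the values given here, no measured step tells how methoxycarbonyl behaves there. Some return toward compound 1 is expected, so compound 4 is estimated at 2500 nM, between 500 nM and 10000 nM, which means an expected step of a 2.8-fold lower number from compound 3 to compound 4 (0.45 log units; beyond the scatter), uncertain in size.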

Compound 4, half-maximal inhibitory concentration: 5000 nM
Beside the measured number, compound 4's estimate is 2.0-fold (0.30 log units) below it, within the range that was stated.
By their numbers in this assay, from the lowest: compound 1; then compounds 2, 4 and 3 (each within the scatter of the next).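

In this assay, methoxycarbonyl in place of cyclopentyl on a saturated chain carbon bound to an aromatic nitrogen gives a 1.4-fold lower number from compound 3 to compound 4 (0.15 log units; within the scatter). Two quite different groups at this place, one a carbon ring and one without a ring that carries hydrogen-bond acceptors, thus read alike, and neither returns to the level of compound 1, as a 10-fold higher number from compound 1 to compound 4 (1.00 log units; beyond the scatter) shows. No evidence here explains this result.

From the compounds shown here alone, whether the higher numbers follow from the chain carbon itself or from what it carries remains open. A carboxylic acid or an amine on that carbon could help separate these two readings.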